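The compounds below may be only part of what the source reports. "The series", "measured", "known", "first", "only" and "open" are said of these compounds alone.

Of the compounds shown here, three built on one shared core have been measured. Compound 1 `CS(=O)(=O)Nc1ccc2c(c1)S(=O)(=O)N=C(C1=C(O)C3CCCC3N(Cc3ccc(F)cn3)C1=O)N2` gives 100% in an ADME assay on microsomes from liver (Homo sapiens) for metabolic stability, with a stated time of 60 min, tested at 1 uM; on this read-out higher numbers stand for a more stable compound and lower numbers for a less stable compound. Compound 3 `CS(=O)(=O)Nc1ccc2c(c1)S(=O)(=O)N=C(C1=C(O)C3CCCC3N(Cc3ccc(Cl)cc3)C1=O)N2` gives 90% in this assay. Compound 2 `CS(=O)(=O)Nc1ccc2c(c1)S(=O)(=O)N=C(C1=C(O)[C@H]3CCC[C@H]3N(Cc3ccc(C(F)(F)F)cc3)C1=O)N2` gives 85% in this assay, the lowest of the three numbers: its gap to compound 3 is within the scatter, while its gap to compound 1 is beyond it. Compound 4 `CS(=O)(=O)Nc1ccc2c(c1)S(=O)(=O)N=C(C1=C(O)[C@H]3CCC[C@H]3N(Cc3cccc(C(F)(F)F)c3)C1=O)N2` has not yet been measured and differs from compound 2 in one place: 3-(trifluoromethyl)phenyl in place of 4-(trifluoromethyl)phenyl on a saturated chain carbon bound to an amide-type nitrogen in a ring. Cut one bond further out, the change reads 4-(trifluoromethyl)benzyl to 3-(trifluoromethyl)benzyl. Among the compounds with values here, no measured pair exchanges one trifluoromethylphenyl for another; the only measured swap of a group on that carbon was a number 10 percentage points lower from compound 1 to compound 3 (within the scatter). Compound 4 is therefore expected to move little, with an estimated no change at the digits printed from compound 2 to compound 4 (within the scatter). Compound 4 is estimated at 85%, between 65% and 100%.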

Compound 4, percent of the compound remaining: 70%
For compound 4 the middle estimate is 15 percentage points above the measured one, and the stated range covers the measured number.
By their numbers in this assay, from the lowest: compound 4; then compounds 2, 3 and 1 (each within the scatter of the next, the first and the last beyond it).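

In this assay, putting 3-(trifluoromethyl)phenyl in place of 4-(trifluoromethyl)phenyl gives a number 15 percentage points lower from compound 2 to compound 4 (beyond the scatter) even though the two groups have the same atoms, joined differently. Within the data shown here, at this place, then, how a group's atoms are arranged can matter to the read-out, and this is the first swap here to pass the scatter. Nothing available explains the drop. Still open, as far as these compounds go, is how a nitrile, an amine or a carboxylic acid in place of the trifluoromethyl group would behave. One pair also cannot show whether this step would recur with other groups on that carbon.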